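The compounds below may be only part of what the source reports. "The series", "measured", "known", "first", "only" and "open" are said of these compounds alone.

Measured in an ADME assay on Huh-7 cells (Homo sapiens) for cytotoxicity, with a stated time of 72 h (a higher number here means that more compound is tolerated, a lower number that less compound is tolerated), each value being a limit of the assay and not a number:

Compound 1 `CCOc1cccc2c1S(=O)(=O)N=C2C1=C(O)[C@H](C(C)(C)C)N(CCC(C)(C)C)C1=O`: > 33000 nM
Compound 2 `CCOc1cccc2c1S(=O)(=O)N=C2C1=C(O)[C@H](CC(C)C)N(CCC(C)(C)C)C1=O`: > 33000 nM
Compound 3 `CCOc1cccc2c1S(=O)(=O)N=C2C1=C(O)[C@H](C2CCCCC2)N(CCC(C)(C)C)C1=O`: > 33000 nM

Compound 1 gives no number in this assay, only a limit. The whole set stands at the same ceiling: the limit of > 33000 nM in this assay, at which 3 of the 3 values shown sit.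

Compound 4 `CC(C)(C)CCN1C(=O)C(C2=NS(=O)(=O)c3c(OCC(N)=O)cccc32)=C(O)[C@@H]1C(C)(C)C` keeps the core of compound 1 and changes one group: carbamoyl in place of methyl on a saturated chain carbon bound to an oxygen on an aromatic ring. In other words, carbamoyl takes the place of methyl on a saturated chain carbon bound to an oxygen on an aromatic ring, so that ethoxy becomes carbamoylmethoxy.

The measured steps bear on this only indirectly. They are a step that the two limits leave unreadable from compound 1 to compound 2, a step that the two limits leave unreadable from compound 1 to compound 3 and a step that the two limits leave unreadable from compound 2 to compound 3. All three concern the group on a saturated ring carbon, not the ethoxy group, and none has a size that can be read. Within the data shown here, no step at the changed place has been measured, so no direction can be argued, and no shift beyond the usual scatter is expected. The expected change is a number no higher from compound 1 to compound 4 (the limit leaves the size open). For compound 4 the estimated value is 33000 nM, with an expected range of 14000 nM to 70000 nM.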

Compound 4, half-maximal cytotoxic concentration: > 33000 nM
Compound 4 was reported as a limit; the forecaster's own chance of this, stated with the estimate: 75%; the middle value sits exactly at the limit.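

In this assay, compound 1 and compound 4 are both reported only as limits of the assay, not as numbers, so the step between them cannot be read: the limit of > 33000 nM in this assay, at which 4 of the 4 values shown sit. The compounds shown leave open how far each lies from that limit, and whether replacing ethoxy with carbamoylmethoxy changes the tolerated concentration at all.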